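A few compounds are considered here, and "the series" means these few. Any claim that something is new, unique, unknown or untested is made for them only; others in the source may bear on it.

Measured so far in a physicochemical assay for solubility, read by HPLC, with a stated time of 30 min; on this read-out lower numbers stand for lower solubility and higher numbers for higher solubility:
compound 1 `O=C(Nc1nc(-c2cccc(F)c2)cs1)c1ccc([N+](=O)[O-])o1`, 14.8 ug/mL
compound 2 `CC(C)Oc1cccc(-c2csc(NC(=O)c3ccc([N+](=O)[O-])o3)n2)c1`, 0.27 ug/mL
compound 3 `O=C(Nc1nc(-c2cccc(NC(=O)C3CC3)c2)cs1)c1ccc([N+](=O)[O-])o1`, 0.47 ug/mL

Compound 3 stands second highest of the three numbers in this assay: far from compound 1, with a 31-fold lower number from compound 1 to compound 3 (1.50 log units; beyond the scatter), and close to compound 2, with a 1.7-fold higher number from compound 2 to compound 3 (0.24 log units; within the scatter). Compound 4 `O=C(Nc1nc(-c2cccc(NC(=O)C3CCCCC3)c2)cs1)c1ccc([N+](=O)[O-])o1` differs from compound 3 by cyclohexyl in place of cyclopropyl on a carbonyl carbon. Going by the values given here, no measured step changes the ring on that carbonyl carbon. The steps that touch this part of the molecule are a 55-fold lower number from compound 1 to compound 2 (1.74 log units; beyond the scatter) and a 31-fold lower number from compound 1 to compound 3 (1.50 log units; beyond the scatter), both large, while the exchange between compound 2 and compound 3 was small. On this basis compound 4 is expected to give 0.2 ug/mL in this assay, with a range of 0.05 ug/mL to 0.8 ug/mL, which means an expected step of a 2.4-fold lower number from compound 3 to compound 4 (0.37 log units; beyond the scatter).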

Compound 4, solubility: 3.46 ug/mL
Compound 4: middle estimate off by 17-fold (1.24 log units), on the low side, outside the stated range (above it).
By their numbers in this assay, from the lowest: compounds 2 and 3 (each within the scatter of the next); then compound 4; then compound 1.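

In this assay, going by these compounds alone, cyclohexyl in place of cyclopropyl on a carbonyl carbon gives a 7.4-fold higher number from compound 3 to compound 4 (0.87 log units; beyond the scatter) and so shows that the ring at this place can shift the number, which no earlier step showed. Against isopropoxy the (cyclohexylcarbonyl)amino group gives a 13-fold higher number from compound 2 to compound 4 (1.11 log units; beyond the scatter) while against fluoro it gives a 4.3-fold lower number from compound 1 to compound 4 (0.63 log units; beyond the scatter) and compound 1 stays the highest of the four. Nothing at hand explains this result.

On these data alone, whether the number follows ring size remains open, since cyclobutyl and cyclopentyl on this carbonyl carbon do not appear here. As far as these compounds go, how an amine or a carboxylic acid on the ring would read is also open.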